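A few compounds are considered here, and "the series" means these few. Any claim that something is new, unique, unknown or untested is made for them only; others in the source may bear on it.

Measured so far:
- compound 1 `O=C(NCCNc1nccc(-c2c(-c3cccc(F)c3)nc3sccn23)n1)c1ccc(Cl)cc1`: 2570 nM
- compound 2 `O=C(NCCCNc1nccc(-c2c(-c3cccc(F)c3)nc3sccn23)n1)c1ccc(Cl)cc1`: 13700 nM

In a functional assay on A-375 cells (Homo sapiens) for cytotoxicity, read by MTT assay (a higher number here means a weaker inhibitor, a lower number a stronger inhibitor), compound 2 gives 13700 nM, the highest of the two numbers; compound 1 gives 2570 nM. Compound 3 `O=C(NCCNc1nccc(-c2c(-c3cccc(F)c3)nc3sccn23)n1)c1ccccc1` differs from compound 2 by benzamido in place of (((4-chlorophenyl)carbonyl)amino)methyl on a saturated chain carbon, two bonds along the chain from a nitrogen on an aromatic ring. Within the data shown here, the one measured step that bears on it, a 5.3-fold higher number from compound 1 to compound 2 (0.73 log units; beyond the scatter), went the other way along the chain; the chlorine removal has no measured counterpart. A lower number for compound 3 in this assay is therefore expected, roughly reversing that step, estimated at 3500 nM (range 1200 nM to 10000 nM), a step of a 3.9-fold lower number from compound 2 to compound 3 (0.59 log units; beyond the scatter).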

Compound 3, half-maximal inhibitory concentration: 5060 nM
Estimate against measurement, compound 3: 1.4-fold (0.16 log units) below, within the range that was stated.
By their numbers in this assay, from the lowest: compounds 1 and 3 (each within the scatter of the next); then compound 2.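

In this assay, hydrogen in place of chloro on the aromatic carbon gives a 2.0-fold higher number from compound 1 to compound 3 (0.29 log units; within the scatter), so the chloro group makes no clear difference on the shorter chain. Benzamido in place of (((4-chlorophenyl)carbonyl)amino)methyl gives a 2.7-fold lower number from compound 2 to compound 3 (0.43 log units; beyond the scatter), a change that stands beyond the scatter and so points to the longer chain of compound 2 rather than to its chloro group. No measurement here offers an explanation for these numbers. On these data alone, whether a methoxy or fluoro group in place of the chloro would shift the number stays open, as does the effect of a still longer chain.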